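A Sulfonyl Aryl Exchange and What It Should Bring

A few compounds are considered here, and "the series" means these few. Any claim that something is new, unique, unknown or untested is made for them only; others in the source may bear on it.

Three compounds have been measured in a functional assay on PC-3 cells (Homo sapiens) for inhibition; on this read-out higher numbers stand for weaker inhibition and lower numbers for stronger inhibition:

compound 1 `COc1cc2nc(N3CCN(C(=O)c4cccc5ccccc45)CC3)nc(N)c2cc1OC`: 59000 nM
compound 2 `COc1cc2nc(N3CCN(S(=O)(=O)c4ccccc4[N+](=O)[O-])CC3)nc(N)c2cc1OC`: 35000 nM
compound 3 `COc1cc2nc(N3CCN(S(=O)(=O)c4ccc(C)cc4)CC3)nc(N)c2cc1OC`: 30000 nM

Compound 2 holds the second highest of the three numbers. Its nearest neighbour is compound 3, reached by a 1.2-fold lower number from compound 2 to compound 3 (0.07 log units; within the scatter), a step within the scatter. Compound 1 gives 59000 nM, and compound 2 gives 35000 nM; the two values lie within the scatter of each other, so no order can be read between them.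

Compound 4 `COc1cc2nc(N3CCN(S(=O)(=O)c4ccc(C(=O)O)cc4)CC3)nc(N)c2cc1OC` has not been measured. It differs from compound 2 in one place: 4-carboxyphenyl in place of 2-nitrophenyl on a sulfonyl sulfur.

Going by the values given here, the one measured step that bears on this change is a 1.2-fold lower number from compound 2 to compound 3 (0.07 log units; within the scatter), where another aryl group replaced the 2-nitrophenyl on the same sulfonyl sulfur and the number hardly moved. On that basis the step from compound 2 to compound 4 is expected to stay within the scatter as well, giving an estimated no change at the digits printed from compound 2 to compound 4 (within the scatter). Compound 4 is therefore estimated at 35000 nM, with a range from 15000 nM to 80000 nM.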

Compound 4, half-maximal inhibitory concentration: 53000 nM
Beside the measured number, compound 4's estimate is 1.5-fold (0.18 log units) below it; measured number inside the range.
By their numbers in this assay, from the lowest: compounds 3, 2, 4 and 1 (each within the scatter of the next).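

In this assay, placing 4-carboxyphenyl on the sulfonyl sulfur gave a 1.5-fold higher number from compound 2 to compound 4 (0.18 log units; within the scatter), so this position now holds a carboxy-bearing aryl group as well as the two earlier aryl groups with no change that can be read. Carboxy in place of methyl on an aromatic carbon gave a 1.8-fold higher number from compound 3 to compound 4 (0.25 log units; within the scatter), which extends the same flat picture to a single-group exchange on the ring. No evidence at hand bears on why these numbers stay so close.

The compounds shown leave open whether an aminomethyl group or a methyl ester on the same aryl ring would move the number beyond the scatter. They also leave open whether replacing the aryl group on the sulfonyl sulfur with a plain alkyl chain would do so.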